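Repeating a Fluoro Swap on a Second Core

This account rests on a few compounds, and the source may have more. Where it says the series, first, only, none or still open, it means among the compounds named here.

Compound 1 `[O-]/[N+](=C\c1cn(-c2ccccc2)nn1)c1ccccc1`: > 100000 nM
Compound 2 `[O-]/[N+](=C\c1cn(-c2ccc(F)cc2)nn1)c1ccccc1`: 9800 nM
Compound 3 `CC(C)(C)/[N+]([O-])=C/c1cn(-c2ccccc2)nn1`: 14800 nM

In a functional assay on MDA-MB-231 cells (Homo sapiens) for inhibition, read by MTT assay, with a stated time of 24 h (on this read-out higher numbers stand for weaker inhibition and lower numbers for stronger inhibition), compound 1 gives only a limit of the assay, (the limit of > 100000 nM in this assay, at which 1 of the 3 values shown sits). Compound 2 differs from it by fluoro in place of hydrogen on an aromatic carbon and gives a number, so the step of an at least 10-fold lower number from compound 1 to compound 2 (1.00 log units; beyond the scatter) is at least modest. Compound 3 differs from compound 1 by tert-butyl in place of phenyl on a double-bonded nitrogen, and the step of an at least 6.7-fold lower number from compound 1 to compound 3 (0.82 log units; beyond the scatter) is also beyond the scatter. Compounds 2 and 3 lie within the scatter of each other, so no order between them is claimed.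

Compound 4 `CC(C)(C)/[N+]([O-])=C/c1cn(-c2ccc(F)cc2)nn1` is not yet measured. It differs from compound 3 by fluoro in place of hydrogen on an aromatic carbon, the same change that turned compound 1 into compound 2. On the core of compound 3 the step of a 3.3-fold lower number from compound 3 to compound 4 (0.52 log units; beyond the scatter) is expected to be smaller than the earlier one, since compound 3 already gives a number, 14800 nM, rather than a limit. Compound 4 is estimated at 4500 nM in this assay, between 1500 nM and 15000 nM.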

Compound 4, half-maximal inhibitory concentration: 66400 nM
Compound 4: the middle estimate sits 15-fold (1.17 log units) below what was measured, and the stated range ends below it.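

In this assay, fluoro in place of hydrogen on an aromatic carbon does not carry over from the core of compound 1 to the core of compound 3, where it gives a 4.5-fold higher number from compound 3 to compound 4 (0.65 log units; beyond the scatter), the opposite direction to the first step: the same change on two cores in this assay, an at least 10-fold lower number (1.00 log units; beyond the scatter) from compound 1 to compound 2 and a 4.5-fold higher number (0.65 log units; beyond the scatter) from compound 3 to compound 4, at least 45-fold (1.66 log units) apart, beyond the scatter of two such steps
Tert-butyl in place of phenyl on a double-bonded nitrogen reverses direction in the same way, giving a 6.8-fold higher number from compound 2 to compound 4 (0.83 log units; beyond the scatter): the same change on two cores in this assay, an at least 6.7-fold lower number (0.82 log units; beyond the scatter) from compound 1 to compound 3 and a 6.8-fold higher number (0.83 log units; beyond the scatter) from compound 2 to compound 4, at least 45-fold (1.66 log units) apart, beyond the scatter of two such steps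
So across these four compounds, the outcome of each change depends on what sits at the other place, but the numbers do not show why, nor how either change would behave on any further core.

From the compounds shown here alone, compound 1 gives > 100000 nM, which is a limit of the assay and not a number, so the full size of its steps stays open. Also open, going by these compounds, is whether a chloro or methoxy group on the aromatic ring, or a longer chain or an amine in place of tert-butyl, would follow compound 2 or compound 4.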